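The source may report more compounds than this note shows. Statements on the series, on what has been measured and on what is new or still open speak of the compounds shown alone.

Compound 2, with the structure `CC(C)[C@H](NC(=O)COc1cccc2ccccc12)C(=O)N[C@@H](CC(=O)O)C(=O)COc1nc2ccccc2[nH]1`, is the starting point here. In a functional assay on Jurkat cells (Homo sapiens) for inhibition (on this read-out higher numbers stand for weaker inhibition and lower numbers for stronger inhibition), compound 2 gives > 200000 nM, which is a limit of the assay rather than a measured number. Among the compounds with values here, the one other compound measured so far, compound 1 with the structure `CC(C)[C@H](NC(=O)COc1cccc2ccccc12)C(=O)N[C@@H](CC(=O)O)C(=O)CSc1nnnn1C`, shares the same core but carries a different group on the saturated chain carbon bound to a carbonyl carbon. In this assay compound 1 gives > 200000 nM, again a limit and not a number. Within the data shown here, the single step that could be read between these two, a step that the two limits leave unreadable from compound 1 to compound 2, therefore has no readable size, because of the limit of > 200000 nM in this assay, at which 2 of the 2 values shown sit.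

Compound 3, with the structure `CC(C)[C@H](NC(=O)COc1cccc2ccccc12)C(=O)N[C@@H](CC(=O)O)C(=O)COc1ccc2ccccc2n1`, differs from compound 2 only in that (quinolin-2-yl in place of 1H-benzimidazol-2-yl on an oxygen on a saturated carbon). Among the measured compounds shown here, no measured step speaks to this change, and the two values that exist are both limits. The expected step of a number no higher from compound 2 to compound 3 (the limit leaves the size open) is therefore no more than a guess that compound 3 stays near where compound 2 sits. Compound 3 is estimated at 200000 nM in this assay, within a range from 30000 nM to 1000000 nM.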

Compound 3, half-maximal inhibitory concentration: > 200000 nM
Compound 3 gave a limit, no number (the forecaster's own chance of this, stated with the estimate: 75%); the middle value lies on the limit itself.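

Within the data shown here, no step in size can be read among compound 1, compound 2 and compound 3, because all three give a limit and not a number: the limit of > 200000 nM in this assay, at which 3 of the 3 values shown sit.

The compounds shown leave open how strongly any of the three inhibits in this assay and whether the groups exchanged on the shared core make any difference to that inhibition.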